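The source may hold more compounds than are shown below. What is called first, only, known or untested is meant among the compounds shown, and "the series" means these compounds.

Working notes on the series. Three measured analogues share one core and differ only on the saturated chain carbon bound to the amide-type nitrogen in the ring. In a functional assay on HeLa cells (Homo sapiens) for cytotoxicity, read by cell counting, with a stated time of 4 days (on this read-out lower numbers stand for stronger inhibition and higher numbers for weaker inhibition), compound 1 `Nc1ccc(/C=C2\SC(=O)N(Cc3ccccc3)C2=O)cc1` gives 46000 nM. Compound 2 `Nc1ccc(/C=C2\SC(=O)N(Cc3ccc(F)cc3)C2=O)cc1` gives 186000 nM, and compound 3 `Nc1ccc(/C=C2\SC(=O)N(Cc3cccc(Cl)c3)C2=O)cc1` gives 24000 nM. Compound 3 has the lowest of the three numbers; one of its gaps is within the scatter (a 1.9-fold lower number from compound 1 to compound 3 (0.28 log units; within the scatter)), the other is not (a 7.8-fold lower number from compound 2 to compound 3 (0.89 log units; beyond the scatter)). Compound 4 `CN1C(=O)S/C(=C\c2ccc(N)cc2)C1=O` differs from compound 3 by hydrogen in place of 3-chlorophenyl on a saturated chain carbon bound to an amide-type nitrogen in a ring. Going by the values given here, no measured step removes the 3-chlorophenyl outright; the nearest, a 7.8-fold lower number from compound 2 to compound 3 (0.89 log units; beyond the scatter), exchanges it for 4-fluorophenyl and moves the number beyond the scatter, and a 4.0-fold higher number from compound 1 to compound 2 (0.61 log units; beyond the scatter) shows a single fluoro doing the same. Direction is uncertain; a modest rise is expected, a 2.9-fold higher number from compound 3 to compound 4 (0.46 log units; beyond the scatter). Compound 4 is estimated at 70000 nM, within 15000 nM to 300000 nM.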

Compound 4, half-maximal inhibitory concentration: 97000 nM
Compound 4: middle estimate off by 1.4-fold (0.14 log units), on the low side; measured number inside the range.
By their numbers in this assay, from the lowest: compounds 3 and 1 (each within the scatter of the next); then compounds 4 and 2 (each within the scatter of the next).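

Going by these compounds alone, compound 4 is the first to lack an aromatic ring on this saturated chain carbon, and the effect of that loss depends on the group removed. Both a 4.0-fold higher number from compound 3 to compound 4 (0.61 log units; beyond the scatter) and a 2.1-fold higher number from compound 1 to compound 4 (0.32 log units; beyond the scatter) lie beyond the scatter, whereas a 1.9-fold lower number from compound 2 to compound 4 (0.28 log units; within the scatter) stays within it, so compound 2 goes against any general gain from keeping the ring. No evidence at hand accounts for these differences. The compounds shown leave open how a longer chain or an amine on this saturated chain carbon would compare.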